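Removing one methoxy from a tolerated styryl-type compound

The source may report more compounds than this note shows. Statements on the series, on what has been measured and on what is new or still open speak of the compounds shown alone.

Compound 1 `COc1cc(/C=C/c2cc(SC)nc(N)n2)cc(OC)c1OC`: "not determined" (no result reported)
Compound 2 `COc1ccc(/C=C/c2cc(SC)nc(N)n2)cc1OC`: 125000 nM

For the measured compounds named here, in an ADME assay on Vero cells (Chlorocebus sabaeus) for cytotoxicity, read by MTT assay, with a stated time of 72 h (a lower number here means that less compound is tolerated, a higher number that more compound is tolerated), compound 2 stands alone with 125000 nM, the only number available, while compound 1 has no result, so there is nothing to rank it against. The next compound to be tested is compound 3 `COc1ccc(/C=C/c2cc(SC)nc(N)n2)cc1`. It differs from compound 2 at a single place: hydrogen in place of methoxy on an aromatic carbon. Going by the values given here, no measured pair shows what such a change does in this assay, so the expectation is a step no larger than the scatter, with no direction favoured. The expected change is a 1.2-fold lower number from compound 2 to compound 3 (0.08 log units; within the scatter). The only anchor for this is compound 2 at 125000 nM. For compound 3 the estimated value is 105000 nM, within an expected range of 40000 nM to 260000 nM.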

Compound 3, half-maximal cytotoxic concentration: 250000 nM
Estimate against measurement, compound 3: 2.4-fold (0.38 log units) below, within the range that was stated.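

In this assay, for the compounds shown here, the pair gives the first reading of a single change on this series: hydrogen in place of methoxy on an aromatic carbon, ortho to a methoxy group and meta to a large group, gives a 2.0-fold higher number from compound 2 to compound 3 (0.30 log units; within the scatter). At this place, then, the two compounds cannot be told apart in this assay, and the methoxy group can leave without a step beyond the scatter. Nothing available explains this result, and no measurement of any property of either compound bears on it.

The compounds shown leave open whether an amine, a hydroxyl or a longer chain such as ethoxy at this place would give a step beyond the scatter. They also leave open what happens when the methoxy that remains on compound 3 gives way to hydrogen.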